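Methyl to hydrogen on the five-membered ring: two cores

A few compounds are considered here, and "the series" means these few. Any claim that something is new, unique, unknown or untested is made for them only; others in the source may bear on it.

Compound 1 `Cc1cnn(C(=O)N(C)CCN(C)Cc2ccc(OCc3ccccc3)cc2)c1` and compound 2 `CN(CCN(C)C(=O)n1cccn1)Cc1ccc(OCc2ccccc2)cc1` share one core; compound 3 `Cc1cnn(C(=O)N2CCN(C(c3ccc4ccccc4c3)c3ccc4ccccc4c3)CC2)c1` and compound 4 `O=C(N1CCN(C(c2ccc3ccccc3c2)c2ccc3ccccc3c2)CC1)n1cccn1` share another. The difference between the two cores is not broken down here. In an assay on membranes from brain for binding affinity to Monoglyceride lipase (Mus musculus), read by fluorescence, with stated times of 1 h and 30 min (on this read-out higher numbers stand for weaker inhibition and lower numbers for stronger inhibition), compound 1 gives 1200 nM. In this assay compound 2 gives 660 nM. Between the two lies a single change, (hydrogen in place of methyl on an aromatic carbon), and the step it made is a 1.8-fold lower number from compound 1 to compound 2 (0.26 log units; within the scatter). Among the compounds with values here, compound 3 still carries the methyl on its five-membered ring, and in this assay compound 3 gives 260 nM, the lowest of the three numbers so far, with compound 2 nearest and compound 1 furthest, both beyond the scatter. Compound 4 has not been measured; it differs from compound 3 by hydrogen in place of methyl on an aromatic carbon, the same change as from compound 1 to compound 2, made at the same place on the ring. Within the data shown here, the only guide is the one earlier step, so the expectation rests on that step, a 1.8-fold lower number from compound 1 to compound 2 (0.26 log units; within the scatter), applied to the starting number of compound 3, 260 nM. For compound 4 the expected step is a 1.4-fold lower number from compound 3 to compound 4 (0.16 log units; within the scatter), a size that stays within the scatter. Compound 4 is therefore estimated at 180 nM in this assay, with a likely range from 70 nM to 500 nM.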

Compound 4, half-maximal inhibitory concentration: 1800 nM
For compound 4 the middle estimate is 10-fold (1.00 log units) below the measured one, and the stated range ends below it.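

In this assay, going from 4-methyl-1H-pyrazol-1-yl to 1H-pyrazol-1-yl on the core of compound 3 gives a 6.9-fold higher number from compound 3 to compound 4 (0.84 log units; beyond the scatter), so on this core the methyl goes with the stronger inhibition. The step measured on the core of compound 1 therefore does not serve as a guide to the same change on the core of compound 3, as the two steps differ by more than the scatter allows: the same change on two cores in this assay, a 1.8-fold lower number (0.26 log units; within the scatter) from compound 1 to compound 2 and a 6.9-fold higher number (0.84 log units; beyond the scatter) from compound 3 to compound 4, 13-fold (1.10 log units) apart, beyond the scatter of two such steps. This shows that the effect of this change depends on the core in these two pairs, but it does not show which part of the core is responsible, why the steps differ, or how the change would read on any third core, and two pairs establish no rule for the series.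

Still open, as far as these compounds go, is how ethyl, chlorine or methoxy at the same aromatic carbon would read on each of the two cores, and whether the gap between the cores would persist with such groups. Also open, from the compounds shown here alone, is whether a core carrying an amine or a carboxylic acid on its large group would follow the core of compound 1, the core of compound 3, or neither.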